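The compounds below may be only part of what the source reports. "The series", "measured", "known", "first", "only" and "open" are said of these compounds alone.

Of the compounds shown here, two of a shared core have already been measured. Compound 1 `N=C(NCCCc1c[nH]cn1)NC(=O)CC(c1ccccc1)c1ccc(F)c(F)c1` gives 81% in a functional assay on cardiac atrium for agonist activity at histamine H2 receptor (Cavia porcellus) (on this read-out higher numbers stand for larger maximal responses and lower numbers for smaller maximal responses), and compound 2 `N=C(NCCCc1c[nH]cn1)NC(=O)CC(c1ccc(F)c(F)c1)c1nccs1` gives 90% in the same assay. Within the data shown here, the only measured step, a number 9 percentage points higher from compound 1 to compound 2 (within the scatter), does not rise above the scatter, so the two compounds cannot be told apart on this number. Compound 2 holds the higher of the two values shown, but its nearest neighbour, compound 1, sits within the scatter of it.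

Compound 3 `N=C(NCCCc1c[nH]cn1)NC(=O)CC(c1ccc(F)c(F)c1)c1nccn1Cc1ccccc1` has not yet been measured. It differs from compound 2 in one place: 1-benzyl-1H-imidazol-2-yl in place of 1,3-thiazol-2-yl on a saturated chain carbon bound to an aromatic carbon and a saturated chain carbon. Among the measured compounds shown here, the one measured step bears on this change only loosely, since it also swapped the group on the same saturated chain carbon and left the maximal response where it was. For the measured compounds named here, a larger group now enters, and no measured step shows what such a group does here, so a modest change in either direction is plausible.

For compound 3 the maximal response in this assay is expected near 80%, with a likely range from 55% to 100%, which is a step of a number 10 percentage points lower from compound 2 to compound 3 (within the scatter) and is not expected to exceed the scatter clearly.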

Compound 3, largest response reached (Emax), in percent of the reference or control that the assay uses: 54%
Estimate against measurement, compound 3: 26 percentage points above; measured number outside the range, below it.
By their numbers in this assay, from the lowest: compound 3; then compounds 1 and 2 (each within the scatter of the next).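

In this assay, the group on this saturated chain carbon turns out to matter for the maximal response: 1-benzyl-1H-imidazol-2-yl in place of 1,3-thiazol-2-yl gives a number 36 percentage points lower from compound 2 to compound 3 (beyond the scatter), whereas the earlier swap at the same carbon, a number 9 percentage points higher from compound 1 to compound 2 (within the scatter), did not rise above the scatter. The same group in place of phenyl gives a number 27 percentage points lower from compound 1 to compound 3 (beyond the scatter), so the fall appears against both earlier groups and is not tied to one comparison alone. Nothing measured here points to what lies behind this fall.

The new group differs from the earlier ones in two ways at once, carrying an imidazole ring and a benzyl group on that ring, so the compounds shown leave open which of the two goes with the lower response. A 1H-imidazol-2-yl group carrying only a hydrogen on its ring nitrogen, or 1-methyl-1H-imidazol-2-yl with a methyl in place of the benzyl, would help separate the two when placed on the same carbon of the shared core.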